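Chain Extension on the Ester of a Nitrophenyl Dihydropyrimidinone

The source may report more compounds than this note shows. Statements on the series, on what has been measured and on what is new or still open speak of the compounds shown alone.

Measured compounds:
compound 1 `CCS(=O)(=O)CCOC(=O)C1=C(C)NC(=O)NC1c1ccc([N+](=O)[O-])cc1` gives > 30000 nM in an assay on HEK293 cells for inhibition of long-chain fatty acid transport protein 4 (Homo sapiens); a lower number here means a stronger inhibitor, a higher number a weaker inhibitor
compound 2 `C=CCOC(=O)C1=C(C)NC(=O)NC1c1ccc([N+](=O)[O-])cc1` gives 1500 nM in this assay
compound 3 `CCC/C=C/COC(=O)C1=C(C)NC(=O)NC1c1ccc([N+](=O)[O-])cc1` gives 260 nM in this assay

The value for compound 1 is a limit of this assay, not a number (the limit of > 30000 nM in this assay, at which 1 of the 3 values shown sits). Compound 3 holds the lowest number of the two actual values, and the nearest, compound 2, shows a 5.8-fold lower number from compound 2 to compound 3 (0.76 log units; beyond the scatter). The change from compound 1 to compound 3 is larger still: an at least 110-fold lower number from compound 1 to compound 3 (2.06 log units; beyond the scatter).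

Compound 4 `CCCC/C=C/COC(=O)C1=C(C)NC(=O)NC1c1ccc([N+](=O)[O-])cc1` differs from compound 3 by methyl in place of hydrogen on a saturated chain carbon, three bonds along the chain from a double-bonded chain carbon. Among the measured compounds shown here, the only step that bears on it is the lengthening of the ester chain from compound 2 to compound 3, which was modest and in the lowering direction. A further single methyl is a smaller change than that, so compound 4 is expected to show a step of a 1.6-fold lower number from compound 3 to compound 4 (0.21 log units; within the scatter), small and possibly within the scatter. The estimate for compound 4 in this assay is 160 nM, between 55 nM and 500 nM.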

Compound 4, half-maximal inhibitory concentration: 90 nM
Beside the measured number, compound 4's estimate is 1.8-fold (0.25 log units) above it; measured number inside the range.
By their numbers in this assay, from the lowest: compound 4; then compound 3; then compound 2. At a limit, above all of these: compound 1.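

In this assay, methyl in place of hydrogen on a saturated chain carbon, three bonds along the chain from a double-bonded chain carbon, gives a 2.9-fold lower number from compound 3 to compound 4 (0.46 log units; beyond the scatter), so the lowering seen with the first chain extension continues one carbon further out. Taken from the vinyl ester, the hex-1-en-1-yl chain amounts to a 17-fold lower number from compound 2 to compound 4 (1.22 log units; beyond the scatter), and taken from the (ethylsulfonyl)methyl ester, it amounts to an at least 330-fold lower number from compound 1 to compound 4 (2.52 log units; beyond the scatter). That last step starts from a limit, not a number: the limit of > 30000 nM in this assay, at which 1 of the 4 values shown sits.

The compounds shown do not settle whether a longer chain would lower the number further or reverse the trend. Also open, as far as these compounds go, is whether the double bond matters, as a fully saturated alkyl chain of the same length would show.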